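Replacing the bromo group of compound 3 with nitro

The source may report more compounds than this note shows. Statements on the series, on what has been measured and on what is new or still open speak of the compounds shown alone.

Compound 3 `O=C1N=C(N2CCC[C@H]2C(=O)Nc2ccc3ncnc(Nc4cccc(Cl)c4)c3c2)S/C1=C/c1ccccc1Br` carries a 2-bromophenyl group on a double-bonded chain carbon bound to a double-bonded ring carbon. In a functional assay on HepG2 cells (Homo sapiens) for antiproliferative activity, read by MTT assay (a higher number here means a weaker inhibitor, a lower number a stronger inhibitor), compound 3 gives 24300 nM, the highest of the three numbers measured. Compound 1 `Cc1cccc(/C=C2/SC(N3CCC[C@H]3C(=O)Nc3ccc4ncnc(Nc5cccc(Cl)c5)c4c3)=NC2=O)n1` gives 4500 nM and compound 2 `O=C1N=C(N2CCC[C@H]2C(=O)Nc2ccc3ncnc(Nc4cccc(Cl)c4)c3c2)S/C1=C/c1cccs1` gives 4120 nM; the two differ by a 1.1-fold lower number from compound 1 to compound 2 (0.04 log units; within the scatter), while the change to the 2-bromophenyl group brought a 5.4-fold higher number from compound 1 to compound 3 (0.73 log units; beyond the scatter) and a 5.9-fold higher number from compound 2 to compound 3 (0.77 log units; beyond the scatter).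

Compound 4 `O=C1N=C(N2CCC[C@H]2C(=O)Nc2ccc3ncnc(Nc4cccc(Cl)c4)c3c2)S/C1=C/c1ccccc1[N+](=O)[O-]` differs from compound 3 by nitro in place of bromo on an aromatic carbon. Within the data shown here, no measured step swaps one substituent for another on the same phenyl ring; the three steps in hand all exchange the whole aryl group, and only the step to the 2-bromophenyl compound changed the number beyond the scatter. Nothing in the data therefore sets the direction of this step with confidence, and the expected step of a 1.6-fold lower number from compound 3 to compound 4 (0.21 log units; within the scatter) is taken as small with a wide range. Compound 4 is estimated at 15000 nM, between 4000 nM and 50000 nM.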

Compound 4, half-maximal inhibitory concentration: 32500 nM
Beside the measured number, compound 4's estimate is 2.2-fold (0.34 log units) below it, and the stated range covers the measured number.
By their numbers in this assay, from the lowest: compounds 2 and 1 (each within the scatter of the next); then compounds 3 and 4 (each within the scatter of the next).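

Among these compounds, at this place on the phenyl ring, ortho to a large group, this is the first exchange of one substituent for another, and nitro in place of bromo leaves the number within the scatter (a 1.3-fold higher number from compound 3 to compound 4 (0.13 log units; within the scatter)). In this assay, the 2-nitrophenyl group of compound 4 also sits beyond the scatter from the thiophen-2-yl group (a 7.9-fold higher number from compound 2 to compound 4 (0.90 log units; beyond the scatter)) and the 6-methylpyridin-2-yl group (a 7.2-fold higher number from compound 1 to compound 4 (0.86 log units; beyond the scatter)), so among these four compounds both ortho-substituted phenyl compounds carry the higher numbers, with none going against this. No measurement at hand accounts for this result.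

The compounds shown leave open whether the higher numbers follow the phenyl ring itself or the group on it, which a plain phenyl group would separate. As far as these compounds go, whether an amine or a methoxy group at this place would give a similar number also remains open.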